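Replacing isopropyl with 4-cyanobenzyl on the shared core

The compounds below may be only part of what the source reports. "The series", "measured", "known", "first", "only" and "open" are said of these compounds alone.

Compound 1 `CCOC(=O)c1c(C)nc(-c2cccc(C#N)c2)n1OC(C)C`: 6740 nM
Compound 2 `CCOC(=O)c1c(C)nc(-c2cccc(C#N)c2)n1OCc1ccc(OC)cc1`: 6830 nM
Compound 3 `CCOC(=O)c1c(C)nc(-c2cccc(C#N)c2)n1OCc1ccc(C(=O)OC)cc1`: 9470 nM

Of the compounds shown here, three built on one core have been tested in a functional assay on a cell-free system (plasma, Oryctolagus cuniculus) for inhibition, with stated times of 5 min, 1 min and 6 min; on this read-out lower numbers stand for stronger inhibition and higher numbers for weaker inhibition. Compound 1 is not separated from compound 2, as the step of a 1.0-fold higher number from compound 1 to compound 2 (0.01 log units; within the scatter) shows, and the values of compound 1 and compound 3 likewise lie within the scatter of each other, so none of the three can be called stronger or weaker than another.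

Compound 4 `CCOC(=O)c1c(C)nc(-c2cccc(C#N)c2)n1OCc1ccc(C#N)cc1` has not yet been measured. It differs from compound 1 in one place: 4-cyanobenzyl in place of isopropyl on an oxygen on an aromatic ring. Within the data shown here, two measured steps bear on this change. The first, a 1.0-fold higher number from compound 1 to compound 2 (0.01 log units; within the scatter), shows that putting a substituted benzyl group onto this oxygen in place of isopropyl left the read-out essentially unchanged. The second, a 1.4-fold higher number from compound 2 to compound 3 (0.14 log units; within the scatter), shows that swapping the group on the benzyl ring from methoxy to methoxycarbonyl also stayed within the scatter. A nitrile on that ring is a third such variation, and nothing in these two steps suggests it should behave differently.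

The expected step is therefore a 1.1-fold higher number from compound 1 to compound 4 (0.05 log units; within the scatter), nothing beyond the scatter. Compound 4 is estimated to give 7500 nM in this assay, with a range from 4000 nM to 14000 nM.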

Compound 4, half-maximal inhibitory concentration: 4240 nM
Compound 4: the middle estimate sits 1.8-fold (0.25 log units) above what was measured, within the range that was stated.
By their numbers in this assay, from the lowest: compounds 4, 1, 2 and 3 (each within the scatter of the next, the first and the last beyond it).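

In this assay, among these compounds, the nitrile on the benzyl ring gives the only single-place change that clears the scatter: cyano in place of methoxycarbonyl on an aromatic carbon gives a 2.2-fold lower number from compound 3 to compound 4 (0.35 log units; beyond the scatter) and is a modest separation. The other two changes do not separate their compounds, since 4-cyanobenzyl in place of isopropyl on the oxygen gives a 1.6-fold lower number from compound 1 to compound 4 (0.20 log units; within the scatter) and cyano in place of methoxy gives a 1.6-fold lower number from compound 2 to compound 4 (0.21 log units; within the scatter) on the same read-out, so what the group on the benzyl ring does can so far be told only from the pair with methoxycarbonyl. No measurement is available that explains why this one pair separates while the others do not.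

Still open, going by these compounds, is whether an amine or a carboxylic acid on the benzyl ring would widen this small spread of numbers or leave it unchanged. Also open, on these data alone, is whether the benzyl ring matters at all at this oxygen, which a longer chain such as n-butyl in place of isopropyl would help to show.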